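The source may report more compounds than this note shows. Statements on the series, on what has been measured and on what is new or still open speak of the compounds shown alone.

Working notes on the series. The shared core carries an enone linked to a para-substituted phenyl ring. Compound 1 `COc1ccc(C(=O)/C=C/c2cc3ccccc3[nH]c2=O)cc1` bears a methoxy group on that ring, and in a functional assay on SF-268 cells (Homo sapiens) for cytotoxicity, read by sulforhodamine B assay, with a stated time of 24 h (on this read-out higher numbers stand for weaker inhibition of growth and lower numbers for stronger inhibition of growth), compound 1 gives 2850 nM. Compound 2 `O=C(/C=C/c1cc2ccccc2[nH]c1=O)c1ccc(O)cc1` bears a hydroxy group in the same place, and in this assay compound 2 gives 3760 nM. Going by the values given here, the only measured step so far is a 1.3-fold higher number from compound 1 to compound 2 (0.12 log units; within the scatter), so compound 2 stands alongside compound 1 with no separation between the two numbers beyond the scatter.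

Compound 3 `O=C(/C=C/c1cc2ccccc2[nH]c1=O)c1ccc(Cl)cc1` is the next member, differing from compound 2 by chloro in place of hydroxy on an aromatic carbon. Among the compounds with values here, no measured step covers a hydroxy to chloro exchange at this position; the single step available, from compound 1 to compound 2, shows only that swapping methoxy for hydroxy left the number essentially unchanged. On that basis no step beyond the scatter is expected in this assay for compound 3 either, though the basis is thin. For compound 3 the expected number in this assay is 3000 nM, with a range from 1000 nM to 9000 nM. The expected step is a 1.3-fold lower number from compound 2 to compound 3 (0.10 log units; within the scatter).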

Compound 3, concentration for 50% growth inhibition: 7150 nM
Estimate against measurement, compound 3: 2.4-fold (0.38 log units) below; the range from low to high includes it.
By their numbers in this assay, from the lowest: compounds 1, 2 and 3 (each within the scatter of the next, the first and the last beyond it).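

In this assay, going by these compounds alone, the change to chloro from methoxy on this aromatic carbon, para to a large group, is the first to clear the scatter (a 2.5-fold higher number from compound 1 to compound 3 (0.40 log units; beyond the scatter)), though the separation is modest. This shows that the position is not wholly indifferent to the group it carries, which the comparison of methoxy and hydroxy alone did not reveal. The exchange of hydroxy for chloro (a 1.9-fold higher number from compound 2 to compound 3 (0.28 log units; within the scatter)) stays within the scatter, so chloro is separated only from methoxy and not from hydroxy, and nothing at hand indicates what lies behind that separation.

Still open, going by these compounds, is whether an amine, a carboxylic acid or a longer alkoxy chain at this position would widen the spread, and whether fluoro or bromo would track chloro. Also open is how far the numbers would move with a change to the enone or the shared core, since the three compounds shown differ only in the group on this one aromatic carbon.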